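The compounds below may be only part of what the source reports. "The series", "measured", "known", "first", "only" and "open" are said of these compounds alone.

- compound 1 `O=c1c(CCO)c(-c2ccccc2Cl)c2cc(Cl)ccc2n1-c1ccccc1`: 26000 nM
- compound 2 `CC(=O)OCCc1c(-c2ccccc2Cl)c2cc(Cl)ccc2[nH]c1=O`: 27000 nM

In an ADME assay on HepG2 2.2.15 cells (Homo sapiens) for cytotoxicity (on this read-out lower numbers stand for higher toxicity in this test and higher numbers for lower toxicity in this test), compound 2 gives 27000 nM, which lies within the usual scatter of compound 1 at 26000 nM. Compound 3 `CCCCC(=O)OCCc1c(-c2ccccc2Cl)c2cc(Cl)ccc2[nH]c1=O` is not yet measured. It differs from compound 2 by propyl in place of hydrogen on a saturated chain carbon bound to a carbonyl carbon, so that acetoxy becomes (butylcarbonyl)oxy. Within the data shown here, no measured pair shows this kind of change, so the direction remains open. The estimated change, a 1.1-fold lower number from compound 2 to compound 3 (0.05 log units; within the scatter), is expected to stay within the scatter. Compound 3 is expected to give about 24000 nM, with an estimated range of 10000 nM to 55000 nM.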

Compound 3, half-maximal cytotoxic concentration: 200000 nM
Compound 3: middle estimate off by 8.3-fold (0.92 log units), on the low side, outside the stated range (above it).
By their numbers in this assay, from the lowest: compounds 1 and 2 (each within the scatter of the next); then compound 3.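

In this assay the step from acetoxy to (butylcarbonyl)oxy gives a 7.4-fold higher number from compound 2 to compound 3 (0.87 log units; beyond the scatter) and so moves the number towards lower toxicity in this test. Among these compounds, this shows that the saturated chain carbon bound to the carbonyl carbon is sensitive to added chain length, which no earlier pair could show. Nothing available accounts for the shift.

A single step leaves open whether an ethyl or a longer chain in this place would raise the number further. It also leaves open how a terminal amine or carboxylic acid would behave.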